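Amino for methoxy on the carbon-linked aryl of the triazole series

This account rests on a few compounds, and the source may have more. Where it says the series, first, only, none or still open, it means among the compounds named here.

In a functional assay on MDA-MB-231 cells (Homo sapiens) for cytotoxicity, read by MTT assay (a lower number here means a stronger inhibitor, a higher number a weaker inhibitor), compound 3 `COc1ccc(-c2cn(-c3ccc(OC)cc3)nn2)cc1` stands only at a limit of the assay, > 100 nM, with no number behind it. Compound 1 `Nc1ccc(-c2cn(-c3ccc(OC(F)(F)F)cc3)nn2)cc1` likewise returns only a limit, > 10 nM. Compound 2 `COc1ccc(-n2cc(-c3ccc(N)cc3)nn2)cc1O` also gives a limit, > 10000 nM. Among the compounds with values here, all three values shown are therefore limits, with none sitting at the same one the limit of > 10 nM in this assay, at which 1 of the 3 values shown sits, the limit of > 100 nM in this assay, at which 1 of the 3 values shown sits (the limit of > 10000 nM in this assay, at which 1 of the 3 values shown sits), so no measured step between two numbers exists in this set.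

Compound 4 `COc1ccc(-n2cc(-c3ccc(N)cc3)nn2)cc1` is obtained from compound 3 by the change (amino in place of methoxy on an aromatic carbon), amino in place of methoxy on an aromatic carbon. Compound 1 and compound 2 both carry the same amino group and differ only on the nitrogen-linked aryl, yet their limits fall far apart, so they give no shared direction for the amino group. With compound 3 itself a limit, the expected size of the step from compound 3 to compound 4 is a step that the limit leaves unreadable from compound 3 to compound 4, a move within the scatter at best. For compound 4 the expected value is 1000 nM, with a range from 100 nM to 10000 nM, and a high chance that this assay again reports only a limit.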

Compound 4, half-maximal inhibitory concentration: > 100 nM
Compound 4: a limit, no number; the forecaster's own chance of this, stated with the estimate: 60%; the middle value does not contradict the limit.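

In this assay compound 4 gives > 100 nM as a limit only. Its steps from compound 1, compound 2 and compound 3 cannot be read, as all four values are limits. Still open is whether amino in place of methoxy on an aromatic carbon shifts the result in this assay at all, and how strong any of these compounds is.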